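The source may report more compounds than this note shows. Statements on the series, on what has been measured and on what is new or still open speak of the compounds shown alone.

Compound 3 `Cc1cc(C#N)c2ncc(CSCCc3ccccc3)n2c1` stands at the edge of what the assay reports: in an ADME assay on HEL cells (Homo sapiens) for cytotoxicity, with a stated time of 3 days (a lower number here means that less compound is tolerated, a higher number that more compound is tolerated), compound 3 gives only a limit, > 100 ug/mL. Compound 1 `Cc1cc(N2CCCC2)c2ncc(CSCCc3ccccc3)n2c1` likewise returns a limit, > 100 ug/mL. Compound 2 `Cc1cc(N2CCCC2=O)c2ncc(CSCCc3ccccc3)n2c1` gives a number, 25 ug/mL, so the step of an at least 4.0-fold higher number from compound 2 to compound 3 (0.60 log units; beyond the scatter) is readable, whereas a step that the two limits leave unreadable from compound 1 to compound 3 is not, because of the limit of > 100 ug/mL in this assay, at which 2 of the 3 values shown sit. Compound 4 `Cc1cc(Sc2ccc(O)cc2)c2ncc(CSCCc3ccccc3)n2c1` differs from compound 3 by (4-hydroxyphenyl)sulfanyl in place of cyano on an aromatic carbon. For the measured compounds named here, no measured step carries such a group, so the measured steps bear only loosely on it; the step from compound 2 shows that a change at this carbon can move the number beyond the scatter. Compound 4 is therefore expected to come in under the limit, the step of an at least 1.4-fold lower number from compound 3 to compound 4 (0.15 log units; that floor lies within the scatter) being an estimate. The estimate for compound 4 is 70 ug/mL, within 20 ug/mL to 100 ug/mL.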

Compound 4, half-maximal cytotoxic concentration: 79 ug/mL
The estimate for compound 4 lay 1.1-fold (0.05 log units) below the measured number; measured number inside the range.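

With compound 4, a (4-hydroxyphenyl)sulfanyl group on this aromatic carbon gives a number in this assay, and the change from 2-oxopyrrolidin-1-yl gives a 3.2-fold higher number from compound 2 to compound 4 (0.50 log units; beyond the scatter). The changes from cyano and pyrrolidin-1-yl give an at least 1.2-fold lower number from compound 3 to compound 4 (0.10 log units; that floor lies within the scatter) and an at least 1.2-fold lower number from compound 1 to compound 4 (0.10 log units; that floor lies within the scatter), and neither floor shows a drop beyond the scatter. As far as these compounds go, these two steps stay open-ended because compounds 1 and 3 each give only a limit: the limit of > 100 ug/mL in this assay, at which 2 of the 4 values shown sit. From the compounds shown here alone, what remains open is whether the hydroxyl or the sulfur linkage matters here. A phenylsulfanyl or a phenoxy group at this carbon would separate the two.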